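The compounds below may be only part of what the source reports. "The series", "measured", "known", "first", "only" and "open" are said of these compounds alone.

Among the compounds with values here, compound 1 `CCOC(=O)C1=Cc2ccccc2OC1(OCc1cc(-c2ccc3ccccc3c2)no1)C(F)(F)F` is one of two compounds measured so far in a functional assay on DU-145 cells (Homo sapiens) for inhibition, read by MTT assay, with a stated time of 24 h; a higher number here means a weaker inhibitor, a lower number a stronger inhibitor; in that test compound 1 gives 71800 nM. Compound 2 `CCOC(=O)C1=Cc2ccccc2OC1(OCc1cc(-c2ccc(Br)cc2)no1)C(F)(F)F` differs from it in one aryl group, and in this assay compound 2 gives 71700 nM. The step between them, a 1.0-fold lower number from compound 1 to compound 2 (0.00 log units; within the scatter), is no change beyond the scatter. On the two numbers shown, compound 2 therefore sits alongside compound 1, with the two values within the scatter of each other.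

Compound 3 `CCOC(=O)C1=Cc2ccccc2OC1(OCc1cc(-c2cccc(C(F)(F)F)c2)no1)C(F)(F)F` is not yet measured. Compared with compound 2 it carries 3-(trifluoromethyl)phenyl in place of 4-bromophenyl on an aromatic carbon. Within the data shown here, the only measured step that bears on this change is the one from compound 1 to compound 2, where swapping the aryl group on the same ring carbon left the number unchanged within the scatter. On that basis, no step beyond the scatter is expected from compound 2 to compound 3 in this assay, and the expected step is no change at the digits printed from compound 2 to compound 3 (within the scatter). For compound 3 the estimated value in this assay is 71700 nM, with a likely range from 30000 nM to 170000 nM.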

Compound 3, half-maximal inhibitory concentration: 57300 nM
For compound 3 the middle estimate is 1.3-fold (0.10 log units) above the measured one; measured number inside the range.
By their numbers in this assay, from the lowest: compounds 3, 2 and 1 (each within the scatter of the next).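

At this aromatic carbon of the five-membered ring, next to the ring nitrogen, a third aryl group now gives the same reading in this assay: the 3-(trifluoromethyl)phenyl group yields a 1.3-fold lower number from compound 2 to compound 3 (0.10 log units; within the scatter), and set against the naphthalen-2-yl group it yields a 1.3-fold lower number from compound 1 to compound 3 (0.10 log units; within the scatter). The earlier pair compared only naphthalen-2-yl with 4-bromophenyl, whereas this change also replaces bromine with three fluorines, shifts the substituent from the 4- to the 3-position named on the phenyl ring, and raises the group from 7 to 10 heavy atoms, yet no difference beyond the scatter appears. Nothing available here explains why these three aryl groups read alike.

All three groups are aryl groups built of carbon rings, so the compounds shown leave open whether an amine or a carboxylic acid on that ring, or a plain alkyl chain in its place, would move the number beyond the scatter. They also leave open whether this carbon matters at all next to the rest of the shared core, such as the ethyl ester.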